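Swapping the cinnamoyl aryl ring in a trimethoxybenzophenone amide

A few compounds are considered here, and "the series" means these few. Any claim that something is new, unique, unknown or untested is made for them only; others in the source may bear on it.

The measured compounds and their values:

Compound 1, `COc1cccc(/C=C/C(=O)Nc2cc(OC)c(OC)c(OC)c2)c1`: 3200 nM
Compound 2, `COc1ccc(C(=O)c2cc(OC)c(OC)c(OC)c2)cc1NC(=O)/C=C/c1cc(OC)c(OC)c(OC)c1`: 6300 nM
Compound 3, `COc1cc(C(=O)c2cc(OC)c(OC)c(OC)c2)cc(NC(=O)/C=C/c2cc(OC)c(OC)c(OC)c2)c1OC`: 6600 nM

In a functional assay on DU-145 cells (Homo sapiens) for cytotoxicity, read by MTT assay, with a stated time of 72 h (a lower number here means a stronger inhibitor, a higher number a weaker inhibitor), compound 1 gives 3200 nM. Compound 2 gives 6300 nM in this assay, and compound 3 gives 6600 nM. Compound 3 thus has the highest number of the three; its gap to compound 2 is within the scatter, as the step of a 1.0-fold higher number from compound 2 to compound 3 (0.02 log units; within the scatter) shows, while its gap to compound 1 lies beyond the scatter.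

Compound 4, `C#CCOc1cccc(/C=C/C(=O)Nc2cc(C(=O)c3cc(OC)c(OC)c(OC)c3)cc(OC)c2OC)c1`, has not yet been measured in this assay. It differs from compound 3 in one place: 3-(propargyloxy)phenyl in place of 3,4,5-trimethoxyphenyl on a double-bonded chain carbon bound to a double-bonded chain carbon. For the measured compounds named here, no measured step covers this change. Going by the values given here, the only step that has been measured, a 1.0-fold higher number from compound 2 to compound 3 (0.02 log units; within the scatter), concerns a methoxy on the anilide ring and did not move the number beyond the scatter. Compound 1 carries a different cinnamoyl aryl group than compounds 2 and 3, but it also lacks the benzoyl part, so its value cannot be tied to the aryl swap alone.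

With nothing to guide direction, compound 4 is expected to sit near compound 3, a step of a 1.3-fold lower number from compound 3 to compound 4 (0.12 log units; within the scatter). The estimate for compound 4 in this assay is 5000 nM, with a range from 1500 nM to 16000 nM.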

Compound 4, half-maximal inhibitory concentration: 13500 nM
Beside the measured number, compound 4's estimate is 2.7-fold (0.43 log units) below it; the range from low to high includes it.
By their numbers in this assay, from the lowest: compounds 1, 2 and 3 (each within the scatter of the next, the first and the last beyond it); then compound 4.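

In this assay, the place on a double-bonded chain carbon bound to a double-bonded chain carbon proves sensitive to change: putting 3-(propargyloxy)phenyl in place of 3,4,5-trimethoxyphenyl gives a 2.0-fold higher number from compound 3 to compound 4 (0.31 log units; beyond the scatter), a modest step towards a weaker inhibitor. For the compounds shown here, the only earlier step, methoxy in place of hydrogen on an aromatic carbon, stayed within the scatter at a 1.0-fold higher number from compound 2 to compound 3 (0.02 log units; within the scatter), so this is the first single change to move the number beyond it. The swap removes the three methoxy groups and brings in one propargyloxy group with its triple bond, and no measurement shown here explains the rise.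

The compounds shown do not separate the loss of the methoxy groups from the arrival of the triple bond, and a 3-propoxyphenyl, with a saturated chain in place of the triple bond, or a plain phenyl at this place would speak to that. Going by these compounds, it also remains open whether an amine or a carboxylic acid on this ring would keep the number near that of compound 3 or move it in either direction.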